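The source may hold more compounds than are shown below. What is called first, only, known or untested is meant among the compounds shown, and "the series" means these compounds.

Measured compounds and their values:

Compound 1 `N=C(CCCn1c(Cn2c(=O)n(C3CC3)c3ccncc32)cc2cc(Cl)ccc21)NO` — in an ADME assay on HeLa cells (Homo sapiens) for cytotoxicity, read by ATP content, with a stated time of 3 days (on this read-out higher numbers stand for lower toxicity in this test and lower numbers for higher toxicity in this test), compound 1 gives > 50000 nM, which is a limit of the assay rather than a number.
Compound 2 `N#CCCCn1c(Cn2c(=O)n(-c3ccncc3F)c3ccncc32)cc2cc(Cl)ccc21` — in this assay compound 2 gives > 50000 nM, also a limit.
Compound 3 `CS(=O)(=O)CCCn1c(Cn2c(=O)n(C3CC3)c3ccncc32)cc2cc(Br)ccc21` — in this assay compound 3 gives > 50000 nM, again a limit.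

Compound 1 therefore stands where every value shown stands: at the limit of > 50000 nM in this assay, at which 3 of the 3 values shown sit. No number separates it from compound 2 or compound 3, only shared limits.

The step to compound 4 `NC(=O)CCCn1c(Cn2c(=O)n(C3CC3)c3ccncc32)cc2cc(Cl)ccc21` is the change (a group of 3 heavy atoms (1 carbon, 1 nitrogen, 1 oxygen; no ring) in place of a group of 4 heavy atoms (1 carbon, 2 nitrogen, 1 oxygen; no ring), on a saturated chain carbon, three bonds along the chain from an aromatic nitrogen). No measured pair differs in a single place, so no step size is on record in this assay from which to reason directly; the only guide is that all three compounds shown, with different groups on that chain and elsewhere, reach the limit without a numerical reading.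

On that basis compound 4 is expected to give 50000 nM, with a range of 20000 nM to 100000 nM. The expected step is a number no higher from compound 1 to compound 4 (the limit leaves the size open), none beyond the usual scatter, and most likely a further limit rather than a number.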

Compound 4, half-maximal cytotoxic concentration: > 50000 nM
Compound 4 gave a limit, no number; the forecaster's own chance of this, stated with the estimate: 85%; the middle value lies on the limit itself.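

In this assay compound 4 gives > 50000 nM, a limit of the assay and not a number. Among these compounds, compound 1 also stands at a limit, so no step from compound 1 to compound 4 can be read. The compounds shown leave open whether any of their differences alters this read-out, as all of them share one position: the limit of > 50000 nM in this assay, at which 4 of the 4 values shown sit.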